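Swapping Amino for Fluoro on the Shared Core

The source may report more compounds than this note shows. Statements on the series, on what has been measured and on what is new or still open speak of the compounds shown alone.

Of the compounds shown here, three have been tested in a functional assay on HeLa cells (Homo sapiens) for inhibition; on this read-out lower numbers stand for stronger inhibition and higher numbers for weaker inhibition. Compound 1, with the structure `CC(=O)OC(C)n1cnc2c(Cl)nc(N)nc21`, gives only a limit, > 500000 nM, which is the edge of the assay and not a number. Compound 2, `Nc1nc(I)nc2c1ncn2OCCO`, likewise stops at the limit of > 500000 nM. Compound 3, `CC(=O)OC(C)n1cnc2c(N)nc(I)nc21`, also returns only the limit of > 500000 nM. All three therefore sit at the limit of > 500000 nM in this assay, at which 3 of the 3 values shown sit, so none of them shows measurable inhibition, and compound 1 stands together with the others at that edge rather than anywhere on a scale.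

Compound 4, `CC(=O)OC(C)n1cnc2c(Cl)nc(F)nc21`, differs from compound 1 in one place: fluoro in place of amino on an aromatic carbon. Among the measured compounds shown here, no measured step between two compounds exists to show how such a change moves this assay, so its direction cannot be read from the data. Since every tested compound sits at the limit, compound 4 is expected to remain there as well, an expected step of a number no higher from compound 1 to compound 4 (the limit leaves the size open) that is none beyond the scatter. The estimate for compound 4 is 500000 nM, in the range from 100000 nM to 2000000 nM.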

Compound 4, half-maximal inhibitory concentration: 50000 nM
The estimate for compound 4 lay 10-fold (1.00 log units) above the measured number; measured number outside the range, below it.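

In this assay, fluoro in place of amino on an aromatic carbon gives an at least 10-fold lower number from compound 1 to compound 4 (1.00 log units; beyond the scatter). Among the compounds shown here, compound 4 is the only compound here to return a real number rather than a limit, with the others staying at the edge of the assay: the limit of > 500000 nM in this assay, at which 3 of the 4 values shown sit. This shows that changing a single group at this position, between two ring nitrogen atoms, can be enough to bring inhibition into measurable range, although the true size of the step remains unknown and this one pair cannot show which difference between amino and fluoro matters.

The compounds shown leave open whether another group at this position, such as methoxy or dimethylamino, would give a lower number than fluoro. They also leave open whether the chloro group of compound 4 is needed for this inhibition.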